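Series notes: the step from compound 2 to compound 4

A few compounds are considered here, and "the series" means these few. Any claim that something is new, unique, unknown or untested is made for them only; others in the source may bear on it.

The shared core is seen in compound 2 `Cc1ccccc1CSc1nnc(-c2ccc3c(c2)OCCO3)o1`, compound 1 `O=[N+]([O-])c1cccc(CSc2nnc(-c3ccc4c(c3)OCCO4)o2)c1` and compound 3 `Cc1ccc(CSc2nnc(-c3ccc4c(c3)OCCO4)o2)cc1`. In a functional assay on HeLa cells (Homo sapiens) for antiproliferative activity, read by MTT assay, with a stated time of 48 h (on this read-out lower numbers stand for stronger inhibition and higher numbers for weaker inhibition), compound 2 gives 19000 nM, the lowest of the three numbers; compound 1 gives 35600 nM, within the scatter of compound 2, while compound 3 gives 45400 nM. The one step shown, a 2.4-fold higher number from compound 2 to compound 3 (0.38 log units; beyond the scatter), lies beyond the scatter. Compound 4 `Clc1ccc(CSc2nnc(-c3ccc4c(c3)OCCO4)o2)cc1` differs from compound 2 by 4-chlorophenyl in place of 2-methylphenyl on a saturated chain carbon bound to a sulfur, read one bond further out as 2-methylbenzyl to 4-chlorobenzyl. Going by the values given here, the only comparison that bears on this change is a 2.4-fold higher number from compound 2 to compound 3 (0.38 log units; beyond the scatter), which also removes the 2-methylphenyl; a weakening of similar size is therefore expected, a 2.1-fold higher number from compound 2 to compound 4 (0.32 log units; beyond the scatter). Compound 4 is estimated at 40000 nM, with a range from 18000 nM to 90000 nM.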

Compound 4, half-maximal inhibitory concentration: 28500 nM
Compound 4: middle estimate off by 1.4-fold (0.15 log units), on the high side, within the range that was stated.
By their numbers in this assay, from the lowest: compounds 2, 4, 1 and 3 (each within the scatter of the next, the first and the last beyond it).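

The 4-chlorophenyl group on the saturated chain carbon bound to a sulfur stays within the scatter of the 2-methylphenyl group (a 1.5-fold higher number from compound 2 to compound 4 (0.18 log units; within the scatter)), so a step beyond the scatter does not follow from every replacement of 2-methylphenyl here. Chloro in place of methyl on an aromatic carbon also stays within the scatter (a 1.6-fold lower number from compound 3 to compound 4 (0.20 log units; within the scatter)), leaving compound 4 unresolved from both compound 2 and compound 3, although those two are separated beyond it. No supporting data bear on this result.

As far as these compounds go, whether an amine or a carboxylic acid on the phenyl ring, or a longer chain in place of the benzyl link, would move the values beyond the scatter remains open.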